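The compounds below may be only part of what the source reports. "The series", "measured", "known", "first", "only" and "open" are said of these compounds alone.

Compound 1 `CC(C)[C@H](NC(=O)COc1cccc2ccccc12)C(=O)N[C@@H](CC(=O)O)C(=O)CSc1nnc(-c2ccccc2)o1` in a functional assay on Jurkat cells (Homo sapiens) for inhibition (a lower number here means a stronger inhibitor, a higher number a weaker inhibitor), gives 150000 nM. Compound 2 `CC(C)[C@H](NC(=O)COc1cccc2ccccc12)C(=O)N[C@@H](CC(=O)O)C(=O)CSc1nnnn1C` in this assay reaches only the assay limit of > 200000 nM, so compound 2 has no number of its own. The step of an at least 1.3-fold higher number from compound 1 to compound 2 (0.12 log units; that floor lies within the scatter) stays within the scatter, resting on the limit of > 200000 nM in this assay, at which 1 of the 2 values shown sits, alone. Compound 3 `CC(C)[C@H](NC(=O)COc1cccc2ccccc12)C(=O)N[C@@H](CC(=O)O)C(=O)COc1cc2ccccc2cn1` differs from compound 2 by (isoquinolin-3-yl)oxy in place of (1-methyl-1H-tetrazol-5-yl)sulfanyl on a saturated chain carbon bound to a carbonyl carbon. Among the measured compounds shown here, no measured step covers this exchange; the only known step at the same place stayed within the scatter. The expected step is therefore a number no higher from compound 2 to compound 3 (the limit leaves the size open), not beyond the scatter. Compound 3 is estimated at 200000 nM, range 60000 nM to 600000 nM.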

Compound 3, half-maximal inhibitory concentration: > 200000 nM
Compound 3 ended at the assay's limit; the forecaster's own chance of this, stated with the estimate: 55%; the middle value sits exactly at the limit.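

An aryloxy group, (isoquinolin-3-yl)oxy, now sits at this saturated chain carbon bound to a carbonyl carbon, and in this assay compound 3 gives > 200000 nM, which is a limit of the assay. The exchange for (5-phenyl-1,3,4-oxadiazol-2-yl)sulfanyl gives an at least 1.3-fold higher number from compound 1 to compound 3 (0.12 log units; that floor lies within the scatter), while the step between the two limit compounds cannot be read. With oxygen as well as sulfur on this carbon, the series now ends mostly at the limit: the limit of > 200000 nM in this assay, at which 2 of the 3 values shown sit.

Only compound 1 has a number of its own here. From the compounds shown here alone, whether an amine on this carbon would give a readable value stays open.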